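The source may report more compounds than this note shows. Statements on the series, on what has been measured and on what is new or still open speak of the compounds shown alone.

Two compounds share one core and differ at two places. Compound 1 `O=C(NOCc1ccc(Cl)cc1Cl)c1cn(-c2ccccc2)nc1-c1ccccc1` carries a plain phenyl on one side and a 2,4-dichlorobenzyl on the other; compound 2 `COc1ccc(-c2nn(-c3ccccc3)cc2C(=O)NOCc2ccccc2)cc1` carries a methoxy-bearing phenyl and a plain benzyl. In an ADME assay on HEK-293T cells (Homo sapiens) for antiproliferative activity, read by MTT assay, with a stated time of 48 h, in the presence of a further agent that is not named here (on this read-out lower numbers stand for higher toxicity in this test and higher numbers for lower toxicity in this test), compound 2 gives 201000 nM, the higher of the two numbers, which stands for the lower toxicity of the pair. In this assay compound 1 gives 40200 nM, and the gap between the two lies beyond the usual scatter of repeated measurements.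

Compound 3 `COc1ccc(-c2nn(-c3ccccc3)cc2C(=O)NOCc2ccc(Cl)cc2Cl)cc1` keeps the methoxy-bearing phenyl of compound 2 and takes the other change: 2,4-dichlorophenyl in place of phenyl on a saturated chain carbon bound to an oxygen. Both changes are thus combined in one molecule. Among the measured compounds shown here, no measured pair shows this single change on its own, so the direction can only be read from what compound 1 and compound 2 show together. Compound 3 is expected to move toward the lower number of compound 1 without fully reaching it, and its step is estimated as a 3.1-fold lower number from compound 2 to compound 3 (0.49 log units; beyond the scatter). For compound 3 the estimated value in this assay is 65000 nM, with a range from 20000 nM to 200000 nM.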

Compound 3, half-maximal cytotoxic concentration: 545000 nM
For compound 3 the middle estimate is 8.4-fold (0.92 log units) below the measured one; the measured number lies above the stated range.
By their numbers in this assay, from the lowest: compound 1; then compound 2; then compound 3.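

In this assay, 2,4-dichlorophenyl in place of phenyl on a saturated chain carbon bound to an oxygen gives a 2.7-fold higher number from compound 2 to compound 3 (0.43 log units; beyond the scatter), so with the methoxy-bearing phenyl present, this change points toward lower toxicity in this test. The other change can now also be read alone: with the 2,4-dichlorobenzyl kept, methoxy in place of hydrogen on an aromatic carbon gives a 14-fold higher number from compound 1 to compound 3 (1.13 log units; beyond the scatter), a large step where the chlorine step is modest, and again toward lower toxicity in this test. Nothing available explains either step.

From the compounds shown here alone, each step rests on a single pair, so it remains open whether the chlorine step keeps its direction and size with a plain phenyl in place of the methoxy-bearing one, and whether the methoxy step holds with a plain benzyl. Also open, going by these compounds, is what other groups would do at these two places, such as an amine or a carboxylic acid in place of methoxy, or a longer chain in place of the benzyl.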